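Adding a Second Chloro to the Phenyl Ring

A few compounds are considered here, and "the series" means these few. Any claim that something is new, unique, unknown or untested is made for them only; others in the source may bear on it.

In a functional assay on the whole organism for positive allosteric modulation, with Rattus norvegicus as the target (on this read-out higher numbers stand for an effect only at larger amounts of compound and lower numbers for an effect already at smaller amounts), compound 1 `Cc1nn(C)c2c1C(c1cccc(Cl)c1)=NCCN2` gives 0.63 mg/kg, level with compound 2 `Cc1nn(C)c2c1C(c1cccc(Cl)c1)=NCCN2C` at 0.63 mg/kg, and together they sit lowest of the three numbers, with compound 3 `Cc1nn(C)c2c1C(c1cccc(Cl)c1)=NCCN2N=O` at 1.25 mg/kg furthest away: no change at the digits printed from compound 1 to compound 2 (within the scatter) and a 2.0-fold higher number from compound 1 to compound 3 (0.30 log units; within the scatter). Compound 4 `Cc1nn(C)c2c1C(c1ccc(Cl)c(Cl)c1)=NCCN2` differs from compound 1 by chloro in place of hydrogen on an aromatic carbon. The measured steps all change the nitrogen on the aromatic ring in the ring, not the six-membered aromatic ring of carbon only, so none bears directly on this change; both were small, within the scatter. Compound 4 is therefore expected to show no step beyond the scatter, no change at the digits printed from compound 1 to compound 4 (within the scatter), with an estimated value of 0.63 mg/kg in this assay, ranging from 0.31 mg/kg to 1.25 mg/kg.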

Compound 4, minimum effective dose: 2.5 mg/kg
Compound 4: middle estimate off by 4.0-fold (0.60 log units), on the low side, outside the stated range (above it).
By their numbers in this assay, from the lowest: compounds 1, 2, 3 and 4 (each within the scatter of the next, the first and the last beyond it).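

This is the first change shown on the six-membered aromatic ring of carbon only: in this assay, chloro in place of hydrogen, ortho to a chloro group, gives a 4.0-fold higher number from compound 1 to compound 4 (0.60 log units; beyond the scatter) and so stands apart from the earlier steps on the nitrogen, all within the scatter. This aromatic carbon is therefore a place where one added atom can shift the dose needed for an effect. Nothing measured here explains the shift.

Going by these compounds, whether fluoro, methyl or methoxy in place of this hydrogen would shift the dose in the same way remains open. So does whether the added chloro would give a similar step with methyl on the nitrogen.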